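Methylsulfanyl on the Anilide Ring of Compound 1

A few compounds are considered here, and "the series" means these few. Any claim that something is new, unique, unknown or untested is made for them only; others in the source may bear on it.

Measured compounds in this series:
compound 1, `O=C(Nc1ccccc1)c1cccc(/C=C2\CC(=O)N(c3ccccc3)C2=O)c1`: > 100000 nM
compound 2, `COc1ccc(NC(=O)c2cccc(/C=C3\CC(=O)N(c4ccc(C)cc4)C3=O)c2)cc1`: 93000 nM
compound 3, `CCCCCN1C(=O)C/C(=C\c2cccc(C(=O)NCCCC)c2)C1=O`: > 100000 nM

In an ADME assay on SW480 cells (Homo sapiens) for cytotoxicity, read by MTT assay, with a stated time of 72 h (on this read-out higher numbers stand for weaker inhibition and lower numbers for stronger inhibition), compound 1 reports only a limit of the assay, > 100000 nM, not a number. Compound 3 likewise reaches only a limit in this assay, > 100000 nM. Among the measured compounds shown here, compound 2 is the one member that gives a number in this assay, 93000 nM. Compound 1 therefore stands where most of this small set stands, at the edge of what this assay can record, as shown by the limit of > 100000 nM in this assay, at which 2 of the 3 values shown sit; no step between measured compounds that differ in one place is available, so nothing in the data ties a structural change to a shift in the read-out.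

Compound 4, `CSc1cccc(NC(=O)c2cccc(/C=C3\CC(=O)N(c4ccccc4)C3=O)c2)c1`, is the next member to be run in this assay. Its relation to compound 1 is methylsulfanyl in place of hydrogen on an aromatic carbon. With both neighbours of compound 1 sitting at or close to the upper edge of this assay, the expectation for the step of a number no higher from compound 1 to compound 4 (the limit leaves the size open) is none beyond the scatter, in either direction. Compound 4 is accordingly estimated at 100000 nM, with a range from 40000 nM to 300000 nM, and a strong chance that this assay again returns only a limit.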

Compound 4, half-maximal inhibitory concentration: 74300 nM
For compound 4 the middle estimate is 1.3-fold (0.13 log units) above the measured one, within the range that was stated.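

Among the compounds shown here, this position on the anilide ring gives the first one-place step, with methylsulfanyl in place of hydrogen on an aromatic carbon, in this assay: an at least 1.3-fold lower number from compound 1 to compound 4 (0.12 log units; that floor lies within the scatter). For the compounds shown here, the printed floor of that step lies within the scatter, so the comparison shows only that this group at this place leaves the read-out no higher than the value of compound 1 and does not by itself establish a real gain. The true size of the step stays unknown because the entry for compound 1 is a limit of the assay and not a number: the limit of > 100000 nM in this assay, at which 2 of the 4 values shown sit.

Open, as far as these compounds go, is whether an amine, a carboxylic acid or a longer chain such as butylsulfanyl at this same place would give a number in this assay clearly apart from the upper edge of the assay, and whether methylsulfanyl elsewhere on the anilide ring would read the same. Also open, from the compounds shown here alone, is whether any change to the shared core of compound 1 would bring the series to a read-out far from that edge.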